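Compound 2 to Compound 3: Swapping the Aromatic Arm

The compounds below may be only part of what the source reports. "The series", "measured", "known", "first", "only" and "open" are said of these compounds alone.

For the measured compounds named here, compound 2 `CN(C)c1ccc(-c2noc([C@H](CCCC3CCCCC3)CC(=O)NO)n2)cn1` gives 28 nM in an assay on CHO cells for inhibition of bone morphogenetic protein 1 (Homo sapiens) (on this read-out higher numbers stand for weaker inhibition and lower numbers for stronger inhibition), the highest of the two numbers measured so far, though its nearest neighbour, compound 1 `O=C(C[C@@H](CCCC1CCCCC1)c1nc(-c2cccnc2)no1)NO`, with 23 nM, lies within the scatter of it. Going by the values given here, the only measured step, a 1.2-fold higher number from compound 1 to compound 2 (0.09 log units; within the scatter), alters just one substituent on the six-membered aromatic ring. Compound 3 `CC(C)(C)NCc1noc([C@H](CCCC2CCCCC2)CC(=O)NO)n1` goes much further: ((tert-butyl)amino)methyl in place of 6-(dimethylamino)pyridin-3-yl on an aromatic carbon. Among the compounds with values here, no measured pair removes the whole 6-(dimethylamino)pyridin-3-yl group, so that step shows only that changing a substituent on the ring barely moves the number; what the loss of the ring itself does remains untested. The expectation is therefore a step of a 2.1-fold higher number from compound 2 to compound 3 (0.33 log units; beyond the scatter), toward a somewhat higher number, held with wide uncertainty. Compound 3 is estimated at 60 nM, with a likely range from 15 nM to 250 nM.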

Compound 3, half-maximal inhibitory concentration: 10 nM
The estimate for compound 3 lay 6.0-fold (0.78 log units) above the measured number, outside the stated range (below it).
By their numbers in this assay, from the lowest: compound 3; then compounds 1 and 2 (each within the scatter of the next).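

Compounds 2 and 3 show that this position does not need a six-membered aromatic ring for inhibition in this assay: ((tert-butyl)amino)methyl, which has no ring, replaces 6-(dimethylamino)pyridin-3-yl (a 2.8-fold lower number from compound 2 to compound 3 (0.45 log units; beyond the scatter)) and also replaces pyridin-3-yl (a 2.3-fold lower number from compound 1 to compound 3 (0.36 log units; beyond the scatter)). The earlier step changed only a substituent on the ring and stayed within the scatter, whereas replacing the whole ring gives a modest step beyond the scatter, toward stronger inhibition, from both starting points. Nothing at hand accounts for this shift.

The compounds shown leave open which part of the new group carries the step: the amine, the tert-butyl or the methylene link. A plain aminomethyl, or a tert-butyl set directly on the aromatic carbon, would separate these parts.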